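Methyl placement on the ring of a cyanoguanidine series

The source may report more compounds than this note shows. Statements on the series, on what has been measured and on what is new or still open speak of the compounds shown alone.

Working notes. Of the compounds shown here, three have been measured in a functional assay on the whole organism with Rattus norvegicus as the target, at a dose of 100 mg/kg; a higher number here means more inhibition at the dose given (going by the name of the read-out), a lower number less inhibition. Compound 3 `CC/N=C(/NC#N)NCCCn1nc(-c2ccccc2)ccc1=O` gives 62.9%. Compound 2 `C/N=C(/NC#N)NCCCCCn1nc(-c2ccccc2)ccc1=O` gives 47.6%, the second highest of the three, and compound 1 `CC/N=C(/NC#N)NCCCn1nc(-c2ccccc2)cc(C)c1=O` gives 23.5%. The difference between the cores of compound 2 and compound 3 is not broken down here. Going by the values given here, the one counted step in the set is methyl in place of hydrogen on an aromatic carbon, which produced a number 39.4 percentage points lower from compound 3 to compound 1 (beyond the scatter).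

Compound 4 `C/N=C(/NC#N)NCCCCCn1nc(-c2ccccc2)c(C)cc1=O` has not been measured. It carries the same kind of change on compound 2, (methyl in place of hydrogen on an aromatic carbon), but the place is not identical: in compound 4 the methyl enters ortho to a phenyl group, meta to a group of 1 heavy atom and para to a large group, whereas in compound 1 it entered ortho to a group of 1 heavy atom and meta to the large group and the phenyl group. Among the compounds with values here, with only a single measured precedent, and that at a different place, the expected step is a loss smaller than the earlier one, a number 19.6 percentage points lower from compound 2 to compound 4 (beyond the scatter), resting on compound 2 at 47.6%. Compound 4 is estimated at 28%, expected between 8% and 50%.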

Compound 4, a percentage reported as inhibition, in the whole organism at one dose (the size of the read-out at that dose, not a potency): 28.5%
Beside the measured number, compound 4's estimate is 0.5 percentage points below it; the measured number falls inside the stated range.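

Methyl in place of hydrogen on an aromatic carbon goes with a lower number in both measured pairs in this assay, and the new step is a number 19.1 percentage points lower from compound 2 to compound 4 (beyond the scatter). The size of the loss does not carry over unchanged from one core to the other: the same change on two cores in this assay, a number 39.4 percentage points lower (beyond the scatter) from compound 3 to compound 1 and a number 19.1 percentage points lower (beyond the scatter) from compound 2 to compound 4, 20.3 percentage points apart, beyond the scatter of two such steps This does not show whether the core or the place of the methyl sets the size of the step, since the two pairs differ in both, and in compound 4 the methyl stands ortho to a phenyl group, a place it does not hold in compound 1.

The compounds shown leave open what the same methyl does at each of the two places on the other core, which would separate place from core. Also open, as far as these compounds go, is whether an ethyl, a methoxy group or a chlorine atom at either place gives a loss of similar size, and how a longer chain on the cyanoguanidine affects it.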